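One Methoxy Less: What to Expect of Compound 4

The compounds below may be only part of what the source reports. "The series", "measured", "known", "first", "only" and "open" are said of these compounds alone.

Compound 1, `COc1cc(-c2cc(/C=C/C(=O)c3ccc(N)cc3)[nH]n2)cc(OC)c1OC`: -66%
Compound 2, `COc1ccc(-c2cc(/C=C/C(=O)c3ccc(N)cc3)[nH]n2)cc1OC`: -10%
Compound 3, `COc1cc(C(=O)/C=C/c2cc(-c3cc(OC)c(OC)c(OC)c3)n[nH]2)cc(OC)c1OC`: -91%

These three compounds were measured in a functional assay on OVCAR-5 cells (Homo sapiens) for cytotoxicity, read by sulforhodamine B assay, with a stated time of 48 h, tested at 10 uM; a lower number here means a stronger effect, a higher number a weaker effect of the compound at the concentration tested. Compound 1 and compound 2 differ in one place, (hydrogen in place of methoxy on an aromatic carbon), and that change made a step of a number 56 percentage points higher from compound 1 to compound 2 (beyond the scatter). Compound 3 shares no counted single difference with compound 1; the difference between the two cores is not broken down here. Compound 4, `COc1ccc(-c2cc(/C=C/C(=O)c3cc(OC)c(OC)c(OC)c3)[nH]n2)cc1OC`, differs from compound 3 by hydrogen in place of methoxy on an aromatic carbon, the same change that separates compound 1 from compound 2. On the strength of that earlier step, compound 4 is expected to move by a number 51 percentage points higher from compound 3 to compound 4 (beyond the scatter) in this assay, though the larger starting effect of compound 3 may leave somewhat more activity behind. Compound 4 is therefore estimated at -40%, between -70% and -5%.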

Compound 4, a percentage reported as activity, at one concentration (the size of the read-out at that concentration, not a potency): -47%
Beside the measured number, compound 4's estimate is 7 percentage points above it, and the stated range covers the measured number.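

In this assay, removing one methoxy again weakened the effect, giving a number 44 percentage points higher from compound 3 to compound 4 (beyond the scatter). Set beside the earlier step, the change carried over from one core to the other with a size that cannot be told apart: the same change on two cores in this assay, a number 56 percentage points higher (beyond the scatter) from compound 1 to compound 2 and a number 44 percentage points higher (beyond the scatter) from compound 3 to compound 4, 12 percentage points apart, within the scatter of two such steps. Within the data shown here, this rests on only two pairs, however, and shows neither why the methoxy matters nor that the step would hold on any further core.

The compounds shown leave open what a hydroxy, an ethoxy or a chlorine atom would do at this place, since only methoxy and hydrogen appear there. They also leave open how far the step would hold at other concentrations, as each read-out comes from a single one.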